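Replacing the Methoxy Group: Expectation for Compound 4

The compounds below may be only part of what the source reports. "The series", "measured", "known", "first", "only" and "open" are said of these compounds alone.

Compound 3 `COc1ccc(-c2nn(-c3ccccc3)cc2C(=O)NOCc2ccc(Cl)cc2Cl)cc1` gives 3830 nM in a functional assay on A549 cells (Homo sapiens) for antiproliferative activity, read by MTT assay, with a stated time of 48 h, in the presence of a further agent that is not named here (a lower number here means a stronger inhibitor of growth, a higher number a weaker inhibitor of growth), the highest of the three numbers, though neither gap to the others exceeds the scatter. Compound 1 `COc1ccc(-c2nn(-c3ccccc3)cc2C(=O)NOCc2ccccc2)cc1` gives 1940 nM and compound 2 `COc1ccc(-c2nn(-c3ccccc3)cc2C(=O)NOCc2ccccc2F)cc1` gives 2160 nM; the steps of a 2.0-fold higher number from compound 1 to compound 3 (0.30 log units; within the scatter) and a 1.8-fold higher number from compound 2 to compound 3 (0.25 log units; within the scatter) remain within the scatter, as does a 1.1-fold higher number from compound 1 to compound 2 (0.05 log units; within the scatter). Compound 4 `O=C(NOCc1ccc(Cl)cc1Cl)c1cn(-c2ccccc2)nc1-c1ccc(Cl)cc1` differs from compound 3 by chloro in place of methoxy on an aromatic carbon. For the measured compounds named here, no measured step touches this group: all three alter the other end of the shared core, and none moves the number beyond the scatter. In this assay a step of a 1.0-fold higher number from compound 3 to compound 4 (0.02 log units; within the scatter) is therefore expected, nothing beyond the scatter. Compound 4 is estimated at 4000 nM, with a range from 1500 nM to 11000 nM.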

Compound 4, concentration for 50% growth inhibition: 13100 nM
The estimate for compound 4 lay 3.3-fold (0.52 log units) below the measured number; the whole stated range lies below it.
By their numbers in this assay, from the lowest: compounds 1, 2 and 3 (each within the scatter of the next); then compound 4.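

For the compounds shown here, the change from 4-methoxyphenyl to 4-chlorophenyl is the only step in this assay to pass the scatter, with a 3.4-fold higher number from compound 3 to compound 4 (0.53 log units; beyond the scatter). The earlier steps all lay at the other end of the shared core, so this position is the only one shown to move the number, though the step is modest and is seen on a single pair. No measured evidence bears on why this exchange gives a higher number. On these data alone, whether the same change would give a like step in compound 1 remains open, as does the effect of a hydroxyl, an amine or a methyl at this position.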